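The source may hold more compounds than are shown below. What is called first, only, known or untested is meant among the compounds shown, and "the series" means these compounds.

Working notes on the series. In a functional assay on SK-MEL-28 cells (Homo sapiens) for inhibition, read by sulforhodamine B assay, with a stated time of 48 h (on this read-out lower numbers stand for stronger inhibition of growth and higher numbers for weaker inhibition of growth), compound 1, `Nc1cc(N)c2nc(-c3ccccc3)c(Sc3ccc(F)cc3)nc2c1`, gives 23400 nM. Among the three numbers measured so far this is the highest. Compound 3, `CCOC(=O)[C@H](CCC(=O)O)NC(=O)c1ccc(Oc2nc3cc(N)cc(N)c3nc2-c2ccccc2)cc1`, gives 14500 nM in this assay, and the gap between compound 1 and compound 3 lies within the scatter, so no order between the two can be read from it. Compound 2, `COc1cc(CNc2nc3cc(N)cc(N)c3nc2-c2ccccc2)cc(OC)c1OC`, gives 8510 nM in this assay, and its gap from compound 1 lies beyond the scatter. Among the compounds with values here, no pair of the measured compounds differs in a single place, so no computed step between measured compounds is available.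

The next compound, compound 4, `Nc1cc(N)c2nc(-c3ccccc3)c(NCc3ccc(F)cc3)nc2c1`, differs from compound 1 in one place: (4-fluorobenzyl)amino in place of (4-fluorophenyl)sulfanyl on an aromatic carbon. The only anchor for a guess is that the measured spread runs from compound 1 down to compound 2, with compound 2 giving 8510 nM in this assay. The step in this assay is expected to be a 2.3-fold lower number from compound 1 to compound 4 (0.37 log units; beyond the scatter), toward a lower number, of a size near the edge of the scatter rather than clearly beyond it. Compound 4 is estimated at 10000 nM in this assay, with an expected range from 4000 nM to 25000 nM.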

Compound 4, concentration for 50% growth inhibition: 1910 nM
Estimate against measurement, compound 4: 5.2-fold (0.72 log units) above; measured number below the stated range.
By their numbers in this assay, from the lowest: compound 4; then compounds 2, 3 and 1 (each within the scatter of the next, the first and the last beyond it).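

On the aromatic carbon next to the ring nitrogen and ortho to a phenyl group, (4-fluorobenzyl)amino in place of (4-fluorophenyl)sulfanyl gives a 12-fold lower number from compound 1 to compound 4 (1.09 log units; beyond the scatter) in this assay. Within the data shown here, this is the first single-place comparison, and it shows that growth inhibition in this read-out depends strongly on the group at this position. The entering group carries a hydrogen-bond donor and the leaving group none, but no measurement on hand accounts for the size of the step.

The step changes both the linking atom and the distance to the fluorinated ring, so the two remain unseparated; (4-fluorophenyl)amino or (4-fluorobenzyl)sulfanyl at this position would divide them. From the compounds shown here alone, the part played by the fluorine also stays open, and an unsubstituted benzylamino group would address it.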